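The source may report more compounds than this note shows. Statements on the series, on what has been measured and on what is new or still open speak of the compounds shown alone.

Compound 1, `COc1cccc(-c2cc(C(=O)Nc3ccc(Oc4ccnc5cc(OCCCN6CCCC6)c(OC)cc45)c(F)c3)c3ccccc3n2)c1`, in a functional assay on MKN-45 cells (Homo sapiens) for cytotoxicity, read by MTT assay, with a stated time of 72 h (a higher number here means a weaker inhibitor, a lower number a stronger inhibitor), gives 430 nM.
Compound 2, `COc1cc2c(Oc3ccc(NC(=O)c4cc(-c5ccc(C)cc5)nc5ccccc45)cc3F)ccnc2cc1OCCCN1CCCC1`, in this assay gives 300 nM.
Compound 3, `COc1cccc(-c2cc(C(=O)Nc3ccc(Oc4ccnc5cc(OCCCN6CCCCC6)c(OC)cc45)c(F)c3)c3cc(F)ccc3n2)c1`, in this assay gives 690 nM.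

Compound 2 differs from compound 1 by one change, (4-methylphenyl in place of 3-methoxyphenyl on an aromatic carbon), and this gave a 1.4-fold lower number from compound 1 to compound 2 (0.16 log units; within the scatter). Compound 4, `COc1cc2c(Oc3ccc(NC(=O)c4cc(-c5ccc(C)cc5)nc5ccc(F)cc45)cc3F)ccnc2cc1OCCCN1CCCCC1`, carries the same change on compound 3: 4-methylphenyl in place of 3-methoxyphenyl on an aromatic carbon. The surroundings of the place are described in the same words for both pairs. The difference between the core of compound 1 and the core of compound 3 is not broken down here. Among the compounds with values here, since the one measured example of this change stayed within the scatter, the step from compound 3 to compound 4 is expected to be similarly small, a 1.4-fold lower number from compound 3 to compound 4 (0.14 log units; within the scatter), because compound 1 to compound 2 showed a 1.4-fold lower number from compound 1 to compound 2 (0.16 log units; within the scatter). Compound 4 is therefore estimated at 500 nM in this assay, between 250 nM and 1000 nM.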

Compound 4, half-maximal inhibitory concentration: 170 nM
Estimate against measurement, compound 4: 2.9-fold (0.47 log units) above, outside the stated range (below it).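

On the core of compound 3, putting 4-methylphenyl in place of 3-methoxyphenyl gave a 4.1-fold lower number from compound 3 to compound 4 (0.61 log units; beyond the scatter) in this assay. The size of this change therefore did not carry over from one core to the other: the same change on two cores in this assay, a 1.4-fold lower number (0.16 log units; within the scatter) from compound 1 to compound 2 and a 4.1-fold lower number (0.61 log units; beyond the scatter) from compound 3 to compound 4, 2.8-fold (0.45 log units) apart, beyond the scatter of two such steps. These two pairs do not show which part of the difference between the core of compound 1 and the core of compound 3 goes with the larger step, and they give no rule for other cores.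

As far as these compounds go, it remains open how 3-methylphenyl or 4-methoxyphenyl would behave at this place on each core. Such groups could help separate the effect of the group's position from that of swapping methoxy for methyl.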